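Adding a 4-nitrophenyl group on the ring nitrogen of compound 3

The compounds below may be only part of what the source reports. "The series", "measured", "known", "first", "only" and "open" are said of these compounds alone.

Compound 3 `O=C1NC(=O)C2(CSC3=C2C(=O)c2ncccc2C3=O)N1` is the bare form of the shared core, with hydrogen on the amide-type nitrogen in the ring. In a functional assay on CCRF-CEM cells (Homo sapiens) for antiproliferative activity, read by MTT assay, with a stated time of 96 h (a higher number here means a weaker inhibitor, a lower number a stronger inhibitor), compound 3 gives 120 nM, the highest of the three numbers measured. Compound 1 `CN(C)c1ccc(N2C(=O)NC3(CSC4=C3C(=O)c3ncccc3C4=O)C2=O)cc1` carries a 4-(dimethylamino)phenyl group on that nitrogen and gives 1 nM; compound 2 `COc1ccc(N2C(=O)NC3(CSC4=C3C(=O)c3ncccc3C4=O)C2=O)cc1` carries a 4-methoxyphenyl group there and gives 50 nM. Compound 4 `O=C1C2=C(C(=O)c3ncccc31)C1(CS2)NC(=O)N(c2ccc([N+](=O)[O-])cc2)C1=O` is not yet measured; it differs from compound 3 in one place: 4-nitrophenyl in place of hydrogen on an amide-type nitrogen in a ring.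

Among the measured compounds shown here, two measured steps bear on this change, both running in the opposite direction. Removing the aryl group gave a 120-fold higher number from compound 1 to compound 3 (2.08 log units; beyond the scatter) and a 2.4-fold higher number from compound 2 to compound 3 (0.38 log units; beyond the scatter), so putting an aryl group on this nitrogen has lowered the number in both cases, though by very different amounts. A 4-nitrophenyl group has not been tested, and nothing here tells whether it behaves more like the dimethylamino or the methoxy case. A lower number is therefore expected for compound 4, with a step of a 6.0-fold lower number from compound 3 to compound 4 (0.78 log units; beyond the scatter) as the estimate. Compound 4 is estimated at 20 nM, with a range from 4 nM to 100 nM.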

Compound 4, half-maximal inhibitory concentration: 1 nM
For compound 4 the middle estimate is 20-fold (1.30 log units) above the measured one; the whole stated range lies above it.
By their numbers in this assay, from the lowest: compounds 1 and 4 (each within the scatter of the next); then compound 2; then compound 3.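

In this assay, among the compounds shown here, the 4-nitrophenyl group on the amide-type nitrogen in a ring gives a 120-fold lower number from compound 3 to compound 4 (2.08 log units; beyond the scatter), so a large step at this position is no longer tied to the 4-(dimethylamino)phenyl group of compound 1, the only aryl group that had given one before. On the aromatic carbon, the change of substituent now reads two ways: nitro in place of methoxy gives a 50-fold lower number from compound 2 to compound 4 (1.70 log units; beyond the scatter), while nitro in place of dimethylamino gives no change at the digits printed from compound 1 to compound 4 (within the scatter), which leaves the methoxy of compound 2 as the one aryl substituent among these compounds that goes against a large step from compound 3. Nothing available explains why nitro and dimethylamino sit level in this assay while methoxy stands apart.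

What the compounds shown leave open is where a plain phenyl group with no substituent would fall, and whether a chlorine, a carboxylic acid or a primary amine on that aromatic carbon would follow nitro and dimethylamino or follow methoxy. They also leave open whether the ring nitrogen needs an aromatic ring at all, since a methyl group or a longer alkyl chain there would test that directly.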